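Aryl ring swap in a sigma-binding series

The compounds below may be only part of what the source reports. "The series", "measured", "known", "first", "only" and "open" are said of these compounds alone.

The series pairs a shared core with a basic amine on a six-carbon chain. Compound 1 `CCN(CC)CCCCCCOc1ccc2oc(-c3ccccc3)cc(=O)c2c1` gives 100 nM in an assay on isolated protein (Cavia porcellus) with Sigma non-opioid intracellular receptor 1 (Homo sapiens) as the target, read by radioligand binding; on this read-out lower numbers stand for stronger inhibition and higher numbers for weaker inhibition. Compound 2 `O=c1cc(-c2ccccc2Cl)oc2ccc(OCCCCCCN3CCC(O)CC3)cc12` gives 29 nM in this assay, the lower of the two numbers shown, and its gap to compound 1 lies beyond the scatter. For the measured compounds named here, no pair of measured compounds differs in only one place, so the two values are taken as they stand and no single change is isolated.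

Compound 3 `COc1ccc(-c2cc(=O)c3cc(OCCCCCCN4CCC(O)CC4)ccc3o2)cc1` is not yet measured in this assay. It differs from compound 2 by 4-methoxyphenyl in place of 2-chlorophenyl on an aromatic carbon. Going by the values given here, no measured pair isolates a change at this aromatic carbon, so the size and direction of the step are open. A small step toward a higher number, within or just beyond the scatter, is expected: a 1.6-fold higher number from compound 2 to compound 3 (0.19 log units; within the scatter). Compound 3 is expected to give 45 nM in this assay, within a range of 15 nM to 130 nM.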

Compound 3, half-maximal inhibitory concentration: 332 nM
Beside the measured number, compound 3's estimate is 7.4-fold (0.87 log units) below it; measured number above the stated range.
By their numbers in this assay, from the lowest: compound 2; then compound 1; then compound 3.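

In this assay, 4-methoxyphenyl in place of 2-chlorophenyl on the aromatic carbon next to the ring oxygen gives an 11-fold higher number from compound 2 to compound 3 (1.06 log units; beyond the scatter), a large step. For the compounds shown here, this is the first change read in one place, and it shows that the aryl group on this carbon can move the number well beyond the scatter while the six-carbon chain and its amine stay the same. No measurement at hand explains the size or direction of this step.

The change replaces both the substituent and its place on the phenyl ring, so the two contributions remain unseparated. A 4-chlorophenyl or 2-methoxyphenyl group on the same carbon, with the same chain and amine, would show whether the chlorine, the methoxy group or the substitution place carries the step.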